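The compounds below may be only part of what the source reports. "The series", "measured", "known", "first", "only" and "open" are said of these compounds alone.

Measured so far in an assay on isolated protein for inhibition of Maltase-glucoamylase (Homo sapiens); on this read-out higher numbers stand for weaker inhibition and lower numbers for stronger inhibition:
compound 1 `COc1ccc(C(c2c(O)c3cc(Cl)ccc3oc2=O)c2c(O)c3cc(Cl)ccc3oc2=O)cc1O` gives 113000 nM;
compound 2 `O=c1oc2ccc(Cl)cc2c(O)c1C(c1cccc(O)c1)c1c(O)c2cc(Cl)ccc2oc1=O` gives 84100 nM;
compound 3 `COc1cc(C(c2c(O)c3cc(Cl)ccc3oc2=O)c2c(O)c3cc(Cl)ccc3oc2=O)cc(OC)c1OC` gives 128000 nM.

Compound 1 and compound 2 differ by one change, (hydrogen in place of methoxy on an aromatic carbon), and the step that change made was a 1.3-fold lower number from compound 1 to compound 2 (0.13 log units; within the scatter). Compound 3 carries a different aryl group on its shared core, the difference being (3,4,5-trimethoxyphenyl in place of 3-hydroxy-4-methoxyphenyl on a saturated chain carbon bound to two aromatic carbons). Compound 4 `COc1ccc(C(c2c(O)c3cc(Cl)ccc3oc2=O)c2c(O)c3cc(Cl)ccc3oc2=O)cc1OC` is not yet measured; it is made from compound 3 by hydrogen in place of methoxy on an aromatic carbon. This is the same kind of change as that from compound 1 to compound 2, but not the same: in compound 1 the methoxy that leaves sits ortho to a hydroxy group and para to a large group, while in compound 3 it sits ortho to a methoxy group, meta to a large group and meta to a methoxy group. Because the earlier step of a 1.3-fold lower number from compound 1 to compound 2 (0.13 log units; within the scatter) was small, the step for compound 4 is expected to be about a 1.2-fold lower number from compound 3 to compound 4 (0.07 log units; within the scatter). Compound 4 is therefore estimated at 110000 nM, likely between 60000 nM and 220000 nM.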

Compound 4, half-maximal inhibitory concentration: 91400 nM
Compound 4: the middle estimate sits 1.2-fold (0.08 log units) above what was measured; the range from low to high includes it.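

In this assay, taking one methoxy group off the aryl ring gives a 1.4-fold lower number from compound 3 to compound 4 (0.15 log units; within the scatter), and this matches the same change on the other core: the same change on two cores in this assay, a 1.3-fold lower number (0.13 log units; within the scatter) from compound 1 to compound 2 and a 1.4-fold lower number (0.15 log units; within the scatter) from compound 3 to compound 4, 1.0-fold (0.02 log units) apart, within the scatter of two such steps.

The other two new comparisons, a 1.1-fold higher number from compound 2 to compound 4 (0.04 log units; within the scatter) and a 1.2-fold lower number from compound 1 to compound 4 (0.09 log units; within the scatter), are also small, so the aryl groups compared here stay within the scatter of one another. This shows that the change has no clear effect on either of these two cores, but not that a clear effect would carry over from one core to another, or that other cores would behave alike.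

The aryl groups shown bear only hydroxy and methoxy groups. From the compounds shown here alone, what an amine or a carboxylic acid on that ring, or a longer chain on its oxygen, would do remains open.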